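Benzyloxy on the Coumarin Core: a Second Test

The source may hold more compounds than are shown below. What is called first, only, known or untested is meant among the compounds shown, and "the series" means these compounds.

Measured compounds:
compound 1 `O=C(NC1CCCCC1)c1cc2ccccc2oc1=O` 500 nM
compound 2 `O=C(Nc1ccccc1Cc1ccccc1)c1cc2ccccc2oc1=O` 910 nM
compound 3 `O=C(NC1CCCCC1)c1cc2ccc(OCc3ccccc3)cc2oc1=O` 64500 nM

The study concerns three measured compounds and one still to be measured, all compared in an in vitro assay on BTI-TN-5B1-4 cells for inhibition of Amine oxidase [flavin-containing] B (Homo sapiens), read by fluorescence; on this read-out lower numbers stand for stronger inhibition and higher numbers for weaker inhibition. In this assay compound 1 gives 500 nM, compound 2 gives 910 nM and compound 3 gives 64500 nM. The difference between the core of compound 1 and the core of compound 2 is not broken down here; their two values lie within the scatter of each other.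

From compound 1 to compound 3 the change is benzyloxy in place of hydrogen on an aromatic carbon, and it produced a 130-fold higher number from compound 1 to compound 3 (2.11 log units; beyond the scatter).

Compound 4 `O=C(Nc1ccccc1Cc1ccccc1)c1cc2ccc(OCc3ccccc3)cc2oc1=O` is not yet measured. It stands to compound 2 as compound 3 stands to compound 1: the change is benzyloxy in place of hydrogen on an aromatic carbon, at the same place as before, so it is the same change. Because the earlier step of a 130-fold higher number from compound 1 to compound 3 (2.11 log units; beyond the scatter) was large, the step from compound 2 to compound 4 is expected to be about a 99-fold higher number from compound 2 to compound 4 (2.00 log units; beyond the scatter), resting only on that single precedent. Compound 4 is accordingly estimated at 90000 nM, with a range from 25000 nM to 300000 nM.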

Compound 4, half-maximal inhibitory concentration: 63500 nM
For compound 4 the middle estimate is 1.4-fold (0.15 log units) above the measured one; measured number inside the range.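

Benzyloxy in place of hydrogen on an aromatic carbon gave a 70-fold higher number from compound 2 to compound 4 (1.84 log units; beyond the scatter) in this assay, so the large weakening seen on the core of compound 1 recurred on the core of compound 2. Set side by side, the two steps do not differ in size: the same change on two cores in this assay, a 130-fold higher number (2.11 log units; beyond the scatter) from compound 1 to compound 3 and a 70-fold higher number (1.84 log units; beyond the scatter) from compound 2 to compound 4, 1.8-fold (0.27 log units) apart, within the scatter of two such steps. Across these two cores the change therefore carried over with its size intact, but this is one pair of cores only: it does not show that the same would hold on any other core, and it does not explain why the inhibition weakens.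

The compounds shown carry only hydrogen or benzyloxy at this place, so it remains open how a methoxy group, a hydroxyl group or an amine there would read in this assay. From the compounds shown here alone, it also remains open whether benzyloxy on another aromatic carbon of the shared core would bring a step of similar size.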